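A Triazole Replaces the Dimethylamino Group on the Chain

This account rests on a few compounds, and the source may have more. Where it says the series, first, only, none or still open, it means among the compounds named here.

Compound 1 `CN(C)CCCn1nc(C2=C(c3cn(C)c4ccccc34)C(=O)NC2=O)c2cccnc21`: in a functional assay on ECa-109 cells (Homo sapiens) for antiproliferative activity, read by MTT assay, with a stated time of 48 h (a higher number here means a weaker inhibitor, a lower number a stronger inhibitor), compound 1 gives > 100000 nM, a limit of the assay.
Compound 2 `CN1CCN(CCCn2nc(C3=C(c4cn(C)c5ccccc45)C(=O)NC3=O)c3cccnc32)CC1`: in this assay compound 2 gives > 100000 nM, again a limit.
Compound 3 `CN(C)CCCn1nc(C2=C(c3cn(C)c4ccccc34)C(=O)N(c3ccccc3)C2=O)c2cccnc21`: in this assay compound 3 gives 5840 nM.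

Going by the values given here, compound 3 thus holds the only number in this assay; the two other values sit at the limit of > 100000 nM in this assay, at which 2 of the 3 values shown sit. Among the compounds with values here, the one readable step is an at least 17-fold lower number from compound 1 to compound 3 (1.23 log units; beyond the scatter). Compound 4 `Cn1cc(C2=C(c3nn(CCCn4cncn4)c4ncccc34)C(=O)N(c3ccccc3)C2=O)c2ccccc21` differs from compound 3 by 1H-1,2,4-triazol-1-yl in place of dimethylamino on a saturated chain carbon, three bonds along the chain from an aromatic nitrogen. Within the data shown here, the only measured step at that place of the chain, a step that the two limits leave unreadable from compound 1 to compound 2, cannot be read, so no step bears on the change with a size. Compound 4 is therefore expected to stay near compound 3, with no step beyond the scatter foreseen. The expected step is a 1.4-fold higher number from compound 3 to compound 4 (0.14 log units; within the scatter). Compound 4 is estimated at 8000 nM, within 2500 nM to 30000 nM.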

Compound 4, half-maximal inhibitory concentration: > 100000 nM
Compound 4 gave a limit, no number; the forecaster's own chance of this, stated with the estimate: 15%; middle value at least 12-fold (1.09 log units) away from the limit.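

Going by these compounds alone, the earlier step at this place of the chain could not be read, so this is the first readable one: 1H-1,2,4-triazol-1-yl in place of dimethylamino, with the phenyl kept, gives an at least 17-fold higher number from compound 3 to compound 4 (1.23 log units; beyond the scatter). The value of compound 4 is a limit, so this size is only a smallest size. With the phenyl in place, the group on the chain thus decides whether a number is obtained at all, and compound 3 alone has one: the limit of > 100000 nM in this assay, at which 3 of the 4 values shown sit.

The compounds shown leave open how a morpholin-4-yl group or a primary amine on the chain would read with the phenyl kept. They also leave open whether a longer chain carrying dimethylamino would hold a number.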